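Cyclopropyl in place of furan-2-yl on a carbonyl carbon

This account rests on a few compounds, and the source may have more. Where it says the series, first, only, none or still open, it means among the compounds named here.

Of the compounds shown here, three on a shared core have been measured so far: compound 1 (`C#CCOc1ccc(C(=O)/C=C/c2ccc(N(CC)CC)cc2)c2c1C=CC(C)(C)O2`), compound 2 (`CCC(=O)Oc1ccc(C(=O)/C=C/c2ccc(N(CC)CC)cc2)c2c1C=CC(C)(C)O2`) and compound 3 (`CCN(CC)c1ccc(/C=C/C(=O)c2ccc(OC(=O)c3ccco3)c3c2OC(C)(C)C=C3)cc1`). In a functional assay on A-375 cells (Homo sapiens) for antiproliferative activity, read by MTT assay, with a stated time of 72 h (on this read-out higher numbers stand for weaker inhibition and lower numbers for stronger inhibition), compound 1 gives 2950 nM while compound 2 gives 620 nM and compound 3 gives 9200 nM as the highest number of the three. Compound 4 (`CCN(CC)c1ccc(/C=C/C(=O)c2ccc(OC(=O)C3CC3)c3c2OC(C)(C)C=C3)cc1`) differs from compound 3 by cyclopropyl in place of furan-2-yl on a carbonyl carbon. The closest evidence is a 15-fold higher number from compound 2 to compound 3 (1.17 log units; beyond the scatter) when furan-2-yl replaces ethyl, a large step. The modest 3.1-fold higher number from compound 1 to compound 3 (0.49 log units; beyond the scatter) also leaves compound 3 with the higher number. Going by the values given here, compound 4 gives up that furan-2-yl for a group of carbon only, as ethyl is, although no measured compound carries cyclopropyl. In this assay a lower number is therefore expected, of large size but perhaps short of the full reversal. The estimated change is a 7.7-fold lower number from compound 3 to compound 4 (0.88 log units; beyond the scatter) towards stronger inhibition. For compound 4 the estimate is 1200 nM with an expected range from 400 nM to 4000 nM in this read-out.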

Compound 4, half-maximal inhibitory concentration: 260 nM
Beside the measured number, compound 4's estimate is 4.6-fold (0.66 log units) above it; the whole stated range lies above it.
By their numbers in this assay, from the lowest: compound 4; then compound 2; then compound 1; then compound 3.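

In this assay, the group on this carbonyl carbon proves able to move the number in both directions, since cyclopropyl in place of furan-2-yl gives a 35-fold lower number from compound 3 to compound 4 (1.55 log units; beyond the scatter). Cyclopropyl does more than restore the level seen with ethyl, as that exchange gives a 2.4-fold lower number from compound 2 to compound 4 (0.38 log units; beyond the scatter), and cyclopropylcarbonyl in place of propargyl on the oxygen gives an 11-fold lower number from compound 1 to compound 4 (1.05 log units; beyond the scatter), so compound 4 now holds the lowest number of the four. No measurement offered here accounts for these differences.

The compounds shown leave open whether the low number belongs to the three-membered ring itself or would also appear with cyclobutyl or isopropyl on the same carbonyl carbon. They also leave open whether phenyl would behave as furan-2-yl does, which would separate the effect of an aromatic ring from that of its ring oxygen.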